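Swapping Chloro for Carbamoyl: What to Expect

The source may hold more compounds than are shown below. What is called first, only, known or untested is meant among the compounds shown, and "the series" means these compounds.

Of the compounds shown here, two sharing one core have been measured in a functional assay on CHO cells for inhibition of metabotropic glutamate receptor 5 (Rattus norvegicus), read by FLIPR and calcium flux; on this read-out lower numbers stand for stronger inhibition and higher numbers for weaker inhibition. Compound 1 `Cc1ccc2ccc(-c3cccc(C#N)c3)cc2n1` carries a cyano group and gives 7.7 nM. For the measured compounds named here, compound 2 `Cc1ccc2ccc(-c3cccc(Cl)c3)cc2n1` carries a chloro group instead and gives 14000 nM, the higher of the two numbers; the single measured step, a 1800-fold higher number from compound 1 to compound 2 (3.26 log units; beyond the scatter), shows how far the chloro compound falls behind the cyano one.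

Compound 3 `Cc1ccc2ccc(-c3cccc(C(N)=O)c3)cc2n1` is not yet measured. It differs from compound 2 in one place: carbamoyl in place of chloro on an aromatic carbon. Going by the values given here, no measured step tracks a carbamoyl group, so the only guide is that compound 2 already stands at the weak end, and that changing the group at this position moved the number greatly once before.

A carbamoyl group is expected to leave compound 3 in the weak range as well, a step of a 2.3-fold lower number from compound 2 to compound 3 (0.37 log units; beyond the scatter). Compound 3 is therefore estimated at 6000 nM, within a range from 600 nM to 60000 nM.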

Compound 3, half-maximal inhibitory concentration: > 10000 nM
Compound 3 ended at the assay's limit (the forecaster's own chance of this, stated with the estimate: 25%); at least 1.6-fold (0.22 log units) between middle value and limit.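

In this assay compound 3 ends at a limit of the assay and not at a number: the limit of > 10000 nM in this assay, at which 1 of the 3 values shown sits.
The step between chloro and carbamoyl therefore cannot be read, so the data do not say which of these two groups gives the weaker inhibition. Carbamoyl in place of cyano can still be read as an at least 1200-fold higher number from compound 1 to compound 3 (3.11 log units; beyond the scatter) and so, among the three compounds shown, chloro and carbamoyl both fall far behind cyano on this aromatic carbon, and compound 1 is the only one with strong inhibition.

As far as these compounds go, whether any other group can match cyano here stays open, and an amine, a carboxylic acid or a methyl ester on the same carbon would each test this. The compounds shown also leave open how cyano would fare elsewhere on this ring.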